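Chain unsaturation in the chromone series: step to compound 4

A few compounds are considered here, and "the series" means these few. Any claim that something is new, unique, unknown or untested is made for them only; others in the source may bear on it.

Measured compounds:
compound 1 `CCCC/C=C\CCCCCCCCCc1cc(=O)c2c(O)cc(O)c(C)c2o1` – 17500 nM
compound 2 `CC/C=C\C/C=C\C/C=C\CCCCCCCc1cc(=O)c2c(O)cc(OCOC)cc2o1` – 17500 nM
compound 3 `CCCCCCCCCCCCCCCc1cc(=O)c2c(O)c(C)c(OCOC)c(C)c2o1` – > 67200 nM

In a functional assay on MCF7 cells (Homo sapiens) for antiproliferative activity, read by MTT assay (on this read-out lower numbers stand for stronger inhibition and higher numbers for weaker inhibition), compound 1 gives 17500 nM and compound 2 gives 17500 nM; these two values lie within the scatter of each other. For compound 3 only a limit is known in this assay, > 67200 nM, and it is a limit of the assay rather than a number; this is the limit of > 67200 nM in this assay, at which 1 of the 3 values shown sits. Compound 3 therefore stands at the weak end of what has been measured, with no numeric value to compare against compounds 1 and 2.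

Compound 4 `CCCCC/C=C\C/C=C\CCCCCCCc1cc(=O)c2c(O)c(C)c(OCOC)c(C)c2o1` has not been measured in this assay. The change from compound 3 is deca-1,4-dien-1-yl in place of octyl on a saturated chain carbon, seven bonds along the chain from an aromatic carbon. Within the data shown here, no step between measured compounds isolates this change, so its size and direction are open. Among the measured compounds shown here, compound 3 sits at a limit, and the only two numeric values in the set, compounds 1 and 2, are moderate. On that basis compound 4 is expected to move toward a numeric value, a step of an at least 1.9-fold lower number from compound 3 to compound 4 (0.28 log units; that floor lies within the scatter) being the working guess. The estimate for compound 4 in this assay is 35000 nM, with an expected range from 12000 nM to 90000 nM, and a real chance that again only a limit is returned.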

Compound 4, half-maximal inhibitory concentration: > 84100 nM
Compound 4 ended at the assay's limit; the forecaster's own chance of this, stated with the estimate: 40%; middle value at least 2.4-fold (0.38 log units) away from the limit.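

In this assay compound 3 returns only a limit of the assay, > 67200 nM. Among these compounds, compound 4 likewise returns only a limit, > 84100 nM, so no step between compound 3 and compound 4 can be read. The compounds shown leave open whether deca-1,4-dien-1-yl in place of octyl shifts the read-out at all, and in which direction.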